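Amide cap variation on the shared core

This account rests on a few compounds, and the source may have more. Where it says the series, first, only, none or still open, it means among the compounds named here.

Among the compounds with values here, compound 3 `CN1[C@@H]2c3[nH]c4ccccc4c3C[C@H]1[C@H](C#N)N1[C@@H](CNC(=O)c3cccc4c3CCCC4)c3[nH]c4ccccc4c3C[C@@H]21` stands highest of the three numbers measured so far in a functional assay on HT-29 cells (Homo sapiens) for cytotoxicity, read by MTT assay, with a stated time of 72 h; on this read-out higher numbers stand for weaker inhibition and lower numbers for stronger inhibition: compound 3 gives 3340 nM. Compound 2 `COc1ccc(C(=O)NC[C@H]2c3[nH]c4ccccc4c3C[C@H]3[C@H]4c5[nH]c6ccccc6c5C[C@@H]([C@H](C#N)N23)N4C)cc1` gives 840 nM, and compound 1 `CN1[C@@H]2c3[nH]c4ccccc4c3C[C@H]1[C@H](C#N)N1[C@@H](CN3C(=O)c4ccccc4C3=O)c3[nH]c4ccccc4c3C[C@@H]21` gives 80 nM; the step of an 11-fold higher number from compound 1 to compound 2 (1.02 log units; beyond the scatter) is large, and the step of a 4.0-fold higher number from compound 2 to compound 3 (0.60 log units; beyond the scatter) is modest.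

Compound 4 `CN1[C@@H]2c3[nH]c4ccccc4c3C[C@H]1[C@H](C#N)N1[C@@H](CNC(=O)/C=C/c3ccccc3)c3[nH]c4ccccc4c3C[C@@H]21` differs from compound 3 in one place: 2-phenylethenyl in place of 1,2,3,4-tetrahydronaphthalen-5-yl on a carbonyl carbon. Within the data shown here, the only measured step at the same place is a 4.0-fold higher number from compound 2 to compound 3 (0.60 log units; beyond the scatter), where one group on the carbonyl carbon was exchanged for another. That step was modest, and the present change is again an exchange of the group on the carbonyl carbon, with the six-membered non-aromatic ring leaving and one double bond outside aromatic rings entering. Compound 1 bears on it less directly, since the step of an 11-fold higher number from compound 1 to compound 2 (1.02 log units; beyond the scatter) altered the whole group on the saturated chain carbon rather than the cap alone. Among the measured compounds shown here, a modest step in this assay is therefore expected, plausibly back toward the number of compound 2, though no measured pair reports this exact group, so the direction remains uncertain. For compound 4 the estimate is 1500 nM (range 500 nM to 5000 nM), meaning an expected step of a 2.2-fold lower number from compound 3 to compound 4 (0.35 log units; beyond the scatter).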

Compound 4, half-maximal inhibitory concentration: 1400 nM
The estimate for compound 4 lay 1.1-fold (0.03 log units) above the measured number; measured number inside the range.
By their numbers in this assay, from the lowest: compound 1; then compounds 2 and 4 (each within the scatter of the next); then compound 3.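

Within this assay, exchanging the group on the carbonyl carbon alone gives a 2.4-fold lower number from compound 3 to compound 4 (0.38 log units; beyond the scatter), so, taken with the earlier step from compound 2 to compound 3, this cap position moves the number in both directions. 2-Phenylethenyl and 4-methoxyphenyl are not separated by a 1.7-fold higher number from compound 2 to compound 4 (0.22 log units; within the scatter), which leaves 1,2,3,4-tetrahydronaphthalen-5-yl as the only one of the three caps that stands apart from the other two. The amide with 2-phenylethenyl still shows an 18-fold higher number from compound 1 to compound 4 (1.24 log units; beyond the scatter), so replacing the whole group on the saturated chain carbon remains a much larger change than any exchange of cap seen here, with the same direction shown by the step from compound 1 to compound 2.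

Open, on these data alone, is whether an amine or a carboxylic acid on the phenyl ring of the 2-phenylethenyl cap, or a longer chain on the carbonyl carbon, would leave the number where compound 4 stands or bring it closer to that of compound 1. Nothing at hand gives a reason for any of these steps.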